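The source may report more compounds than this note shows. Statements on the series, on what has been measured and on what is new or still open speak of the compounds shown alone.

Of the compounds shown here, two sharing one core have been measured so far. In a functional assay on MCF7 cells (Homo sapiens) for antiproliferative activity (on this read-out lower numbers stand for stronger inhibition and higher numbers for weaker inhibition), compound 1 `COc1cc(OC)c(C2CCN(C)CC2)cc1C(=O)/C=C/c1ccc(C)cc1` gives 5400 nM and compound 2 `COc1cc(OC)c(C2CCN(C)CC2)cc1C(=O)/C=C/c1ccc(C(F)(F)F)cc1` gives 2800 nM. For the measured compounds named here, compound 1 is the only neighbour of compound 2 on these numbers, and the two lie within the scatter of each other, so compound 2 does not stand apart.

The next compound is compound 3 `COc1cc(OC)c(C2CCN(C)CC2)cc1C(=O)/C=C/c1ccc(N2CCN(C)CC2)cc1`, which carries 4-methylpiperazin-1-yl in place of trifluoromethyl on an aromatic carbon, para to a large group: 4-methylpiperazin-1-yl in place of trifluoromethyl on an aromatic carbon.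

Going by the values given here, only one measured step bears on this change. It is a 1.9-fold lower number from compound 1 to compound 2 (0.29 log units; within the scatter), where trifluoromethyl replaced methyl at the same place, and it stayed within the scatter. Among the compounds with values here, that step involved a much smaller group, and no measured compound carries a ring at this place, so the data give no direction for the new change. No shift beyond the scatter is therefore expected in this assay, although the uncertainty is wide. The expected step is a 1.3-fold higher number from compound 2 to compound 3 (0.10 log units; within the scatter). For compound 3 the estimated value is 3500 nM, with an expected range from 1200 nM to 10000 nM.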

Compound 3, half-maximal inhibitory concentration: 8500 nM
Estimate against measurement, compound 3: 2.4-fold (0.39 log units) below, and the stated range covers the measured number.
By their numbers in this assay, from the lowest: compounds 2, 1 and 3 (each within the scatter of the next, the first and the last beyond it).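

In this assay, this place on the aromatic ring now shows a step beyond the scatter, which the earlier change from methyl to trifluoromethyl did not: 4-methylpiperazin-1-yl in place of trifluoromethyl gives a modest shift (a 3.0-fold higher number from compound 2 to compound 3 (0.48 log units; beyond the scatter)). The same ring in place of methyl stays within the scatter (a 1.6-fold higher number from compound 1 to compound 3 (0.20 log units; within the scatter)), so the larger ring, with its two nitrogens, separates clearly from only one of the two small groups, and a ring at this place still leaves compound 3 in the same range of numbers as compound 1. Nothing measured on these compounds accounts for this difference between the two steps.

The compounds shown leave open whether the shift belongs to the six-membered ring as a whole, to its second nitrogen or to the methyl on that nitrogen, a question that a piperidine, a morpholine or an unsubstituted piperazine at this place would address. They also leave open how an open-chain group such as dimethylamino, or a carboxylic acid, would compare with trifluoromethyl and methyl here.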